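The source may report more compounds than this note shows. Statements on the series, on what has been measured and on what is new or still open speak of the compounds shown alone.

In a functional assay on SEM cells (Homo sapiens) for cytotoxicity, with a stated time of 72 h (on this read-out lower numbers stand for an effect already at smaller amounts and higher numbers for an effect only at larger amounts of compound), three compounds sharing one core have been measured so far. Compound 1 `C=C[C@@](C)(/C=C/c1ccc(O)cc1)CCC(O)C(C)(C)O` gives > 36600 nM, which is a limit of the assay and not a number. Compound 2 `C=C[C@@](C)(/C=C/c1ccc(O)cc1)CC/C=C(C)/C=C/C(=O)OCC` gives > 36600 nM, again a limit of the assay. Going by the values given here, compound 3 `C=C[C@@](C)(/C=C/c1ccc(O)c(/C=C/C(=O)c2ccccc2)c1)CCC=C(C)C` gives 8000 nM, the only true number among the three, so it is the one firm reference point in this small set.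

Compound 4 `C=C[C@@](C)(/C=C/c1ccc(O)c(/C=C/c2ccc(Cl)c(Cl)c2)c1)CCC=C(C)C` keeps the core of compound 3 and alters a single group: 3,4-dichlorophenyl in place of benzoyl on a double-bonded chain carbon bound to a double-bonded chain carbon. In words, 3,4-dichlorophenyl stands in place of benzoyl on a double-bonded chain carbon bound to a double-bonded chain carbon. Both groups bring a six-membered aromatic ring of carbon only, but the carbonyl of the benzoyl is lost.

Among the compounds with values here, no pair of measured compounds shows a change of this kind, so any expectation here is loose. Starting from compound 3 at 8000 nM, a small move toward lower numbers in this assay is expected, about the size of the usual scatter. The expected change is a 1.6-fold lower number from compound 3 to compound 4 (0.20 log units; within the scatter). Compound 4 is estimated at 5000 nM, with an expected range of 1500 nM to 16000 nM.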

Compound 4, half-maximal effective concentration: > 7500 nM
Compound 4 was reported as a limit; the forecaster's own chance of this, stated with the estimate: 10%; middle value at least 1.5-fold (0.17 log units) away from the limit.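

In this assay compound 4 gives > 7500 nM, which is a limit of the assay and not a number. The step from compound 3 to compound 4 cannot be read, and it has no size. The compounds shown leave open whether 3,4-dichlorophenyl in place of benzoyl changes the value at all, and in which direction.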